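The compounds below may be only part of what the source reports. "The series", "measured", "known", "first", "only" and "open" are said of these compounds alone.

Working notes on the series.

Compound 1 `NC(=O)c1cccc(Cn2cc(-c3ccc4cn[nH]c4c3)ccc2=O)c1` gives 388 nM in an assay for inhibition of MAP kinase-interacting serine/threonine-protein kinase 1 (Homo sapiens), read by luminescence and ADP-Glo, with a stated time of 2 h; on this read-out higher numbers stand for weaker inhibition and lower numbers for stronger inhibition. Compound 2 `O=c1ccc(-c2ccc3cn[nH]c3c2)cn1Cc1cccc(C(F)(F)F)c1` gives 40 nM in this assay. The change between them is trifluoromethyl in place of carbamoyl on an aromatic carbon, and it made a step of a 9.7-fold lower number from compound 1 to compound 2 (0.99 log units; beyond the scatter).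

Compound 3 `NC(=O)c1ccc(Cn2cc(-c3ccc4cn[nH]c4c3)ccc2=O)cc1` sits at a limit of the assay, > 2000 nM, not a number; the relevant limit line is the limit of > 2000 nM in this assay, at which 1 of the 3 values shown sits. The difference between the core of compound 3 and the core of compound 1 is not broken down here.

Compound 4 `O=c1ccc(-c2ccc3cn[nH]c3c2)cn1Cc1ccc(C(F)(F)F)cc1` is not yet measured. Its difference from compound 3 is trifluoromethyl in place of carbamoyl on an aromatic carbon. This is the same kind of change as from compound 1 to compound 2, not the same: there the group sits meta to a large group, here para to a large group.

For this assay the expected step is an at least 3.3-fold lower number from compound 3 to compound 4 (0.52 log units; beyond the scatter), resting on compound 1 and compound 2, which show a 9.7-fold lower number from compound 1 to compound 2 (0.99 log units; beyond the scatter), tempered by the changed place and by compound 3 being known only as a limit. The estimate for compound 4 is 600 nM, between 150 nM and 2500 nM.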

Compound 4, half-maximal inhibitory concentration: 1170 nM
For compound 4 the middle estimate is 2.0-fold (0.29 log units) below the measured one; the measured number falls inside the stated range.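

In this assay the new step is an at least 1.7-fold lower number from compound 3 to compound 4 (0.23 log units; that floor lies within the scatter), a floor only, and it does not go against the direction of the earlier change of carbamoyl to trifluoromethyl. Going by these compounds, compound 3 stands at a limit of the assay, > 2000 nM, not at a number, so the true size of this step remains unknown: the limit of > 2000 nM in this assay, at which 1 of the 4 values shown sits. The result therefore shows that the two steps can be compatible, but it does not show that the change carries from one core to the other with the same size, or with a different one: the same change on two cores in this assay, a 9.7-fold lower number (0.99 log units; beyond the scatter) from compound 1 to compound 2 and an at least 1.7-fold lower number (0.23 log units; that floor lies within the scatter) from compound 3 to compound 4; the limit leaves it open whether they differ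

The compounds shown leave open how a nitrile, a carboxylic acid or an amine would read in place of trifluoromethyl, para to a large group. They also leave open whether a carbamoyl compound with a value inside the range of the assay would allow this change to be sized on a second core.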